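Moving the pyrimidine attachment on an amine nitrogen

This account rests on a few compounds, and the source may have more. Where it says the series, first, only, none or still open, it means among the compounds named here.

In a functional assay on VCaP cells (Homo sapiens) for antiproliferative activity, read by CCK-8 assay, with a stated time of 6 days (on this read-out higher numbers stand for weaker inhibition and lower numbers for stronger inhibition), compound 1 (`C[C@@H](Cn1ccc(-c2ccc(C#N)c(Cl)c2)n1)NS(=O)(=O)c1cn(C)cn1`) gives 13600 nM. Compound 2 (`C[C@@H](Cn1ccc(-c2ccc(C#N)c(Cl)c2)n1)Nc1ccccc1`) gives > 30000 nM, which is a limit of the assay and not a number. Compound 3 (`C[C@@H](Cn1ccc(-c2ccc(C#N)c(Cl)c2)n1)Nc1cncnc1`) gives > 30000 nM, again only a limit. Compound 3 therefore stands at the limit of > 30000 nM in this assay, at which 2 of the 3 values shown sit.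

Compound 4 (`C[C@@H](Cn1ccc(-c2ccc(C#N)c(Cl)c2)n1)Nc1ncccn1`) keeps everything but the ring on the amine nitrogen, with pyrimidin-2-yl in place of pyrimidin-5-yl on an amine nitrogen.

Going by the values given here, no measured step makes this exact change. The closest is the exchange of one ring for another on the same nitrogen, which is a step that the two limits leave unreadable from compound 2 to compound 3. The larger change of replacing the sulfonyl group gave an at least 2.2-fold higher number from compound 1 to compound 2 (0.34 log units; beyond the scatter) and an at least 2.2-fold higher number from compound 1 to compound 3 (0.34 log units; beyond the scatter), and both are only lower bounds.

With nothing pointing to a gain, no step beyond the scatter is expected, and the likeliest outcome is another limit. The expected change is an estimated a number no higher from compound 3 to compound 4 (the limit leaves the size open). Compound 4 is estimated at 30000 nM, with an expected range from 14000 nM to 60000 nM.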

Compound 4, half-maximal inhibitory concentration: 480 nM
Estimate against measurement, compound 4: 63-fold (1.80 log units) above; the measured number lies below the stated range.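

Moving the attachment of the pyrimidine ring on the amine nitrogen, with the atoms unchanged, gives in this assay an at least 62-fold lower number from compound 3 to compound 4 (1.79 log units; beyond the scatter), so the read-out at this position depends on how the ring is joined and not only on what it contains. Pyrimidin-2-yl also separates clearly from phenyl, with an at least 62-fold lower number from compound 2 to compound 4 (1.79 log units; beyond the scatter), and from (1-methyl-1H-imidazol-4-yl)sulfonyl, with a 28-fold lower number from compound 1 to compound 4 (1.45 log units; beyond the scatter), showing that an aromatic ring on this nitrogen need not lose activity, as compound 2 and compound 3 alone had suggested. Both of those compounds remain at a limit of the assay, so the step between them still cannot be read: the limit of > 30000 nM in this assay, at which 2 of the 4 values shown sit.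

The compounds shown leave open whether a pyridin-2-yl ring on the same nitrogen would keep this activity. Also open, going by these compounds, is what a methyl group or an amine on the pyrimidin-2-yl ring would do.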